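The compounds below may be only part of what the source reports. "The series", "measured", "known", "first", "only" and "open" are said of these compounds alone.

Of the compounds shown here, three sharing one core have been measured in a functional assay on the whole organism (Cricetulus griseus) with Cricetinae gen. sp. as the target; a lower number here means that less compound is needed, a higher number that more compound is needed for the effect. Compound 1 `CCc1ccccc1-c1n[nH]c(-c2cccc(OC)c2)n1` gives 4 mg/kg in this assay and stands at the low end of the three numbers. Compound 3 `CCOc1cccc(-c2n[nH]c(-c3ccccc3C)n2)c1` gives 5 mg/kg, which lies within the usual scatter of compound 1. Among the measured compounds shown here, compound 2 `CCCCc1ccccc1-c1n[nH]c(-c2cccc(OC)c2)n1` gives 10 mg/kg, and the step of a 2.5-fold higher number from compound 1 to compound 2 (0.40 log units; beyond the scatter) is the only one-place change among the measured compounds, involving the alkyl chain on the core rather than the group on the other aromatic ring.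

Compound 4 `CCc1ccccc1-c1n[nH]c(-c2cccc(-c3ccccc3)c2)n1` differs from compound 1 by phenyl in place of methoxy on an aromatic carbon. For the measured compounds named here, no measured step touches this position, so the only guidance is indirect: enlarging compound 1 elsewhere, as in the step of a 2.5-fold higher number from compound 1 to compound 2 (0.40 log units; beyond the scatter), raised the number modestly. A similar outcome seems more likely than not, and the estimate for compound 4 is therefore 8 mg/kg, spanning 3 mg/kg to 20 mg/kg, which would mean an expected step of a 2.0-fold higher number from compound 1 to compound 4 (0.30 log units; within the scatter) in this assay.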

Compound 4, dose for half-maximal effect: 10 mg/kg
Compound 4: the middle estimate sits 1.3-fold (0.10 log units) below what was measured, and the stated range covers the measured number.
By their numbers in this assay, from the lowest: compounds 1, 3, 2 and 4 (each within the scatter of the next, the first and the last beyond it).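

In this assay, among the compounds shown here, the position that the earlier compounds left untouched now gives a first reading: phenyl in place of methoxy, on an aromatic carbon meta to a large group, gives a 2.5-fold higher number from compound 1 to compound 4 (0.40 log units; beyond the scatter) and thus goes beyond the scatter. The effect survives at this position with a six-membered aromatic ring of carbon in place of the smaller methoxy, which also removes the hydrogen-bond acceptor, and the rise is as large as that of the other listed change, a 2.5-fold higher number from compound 1 to compound 2 (0.40 log units; beyond the scatter) on the alkyl chain. No measurement offered here explains the rise at this position.

The compounds shown do not separate the arrival of the ring from the departure of the oxygen as the source of the higher number. From the compounds shown here alone, how an amine, a carboxylic acid or a longer alkoxy chain would read at this place remains open.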